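Shortening the basic chain on the shared core

The source may report more compounds than this note shows. Statements on the series, on what has been measured and on what is new or still open speak of the compounds shown alone.

Compound 1 `CN1CCN(CCCCCn2c3c(c4ccccc42)C(=O)c2c[n+]([O-])c4ccccc4c2C3=O)CC1` carries a basic chain on an aromatic nitrogen of the shared core. In a functional assay on HCT-116 cells (Homo sapiens) for cytotoxicity, read by MTT assay, with a stated time of 72 h (a lower number here means a stronger inhibitor, a higher number a weaker inhibitor), compound 1 gives 1220 nM. Compound 2 `CC1(C)OCC(Cn2cc(Cn3c4c(c5ccccc53)C(=O)c3c[n+]([O-])c5ccccc5c3C4=O)nn2)O1` gives 70 nM, and compound 3 `O=C1c2c[n+]([O-])c3ccccc3c2C(=O)c2c1c1ccccc1n2Cc1cn([C@H]2O[C@H](CO)[C@@H](O)[C@H]2O)nn1` gives 710 nM. Compound 1 thus holds the highest of the three numbers; its nearest neighbour is compound 3, within the scatter, while compound 2 sits furthest from it, beyond the scatter. Within the data shown here, the only step between measured compounds that differ in one place is a 10-fold higher number from compound 2 to compound 3 (1.01 log units; beyond the scatter), and that change sits on the aromatic nitrogen itself.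

Compound 4 `CN(C)CCCCn1c2c(c3ccccc31)C(=O)c1c[n+]([O-])c3ccccc3c1C2=O` has not yet been measured. It differs from compound 1 in one place: dimethylamino in place of (4-methylpiperazin-1-yl)methyl on a saturated chain carbon, four bonds along the chain from an aromatic nitrogen. Among the measured compounds shown here, no measured pair alters this chain position, so no step bears directly on the change; the step from compound 2 to compound 3 concerns a different site and is taken only as a sign that the series can move beyond the scatter. With nothing pointing either way, no step beyond the scatter is expected here. Compound 4 is therefore estimated at 1100 nM, with a range of 400 nM to 3000 nM. The expected step, a 1.1-fold lower number from compound 1 to compound 4 (0.04 log units; within the scatter), is expected to stay within the scatter.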

Compound 4, half-maximal inhibitory concentration: 450 nM
Estimate against measurement, compound 4: 2.4-fold (0.39 log units) above; the measured number falls inside the stated range.
By their numbers in this assay, from the lowest: compound 2; then compounds 4, 3 and 1 (each within the scatter of the next, the first and the last beyond it).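

Among these compounds, with a 2.7-fold lower number from compound 1 to compound 4 (0.43 log units; beyond the scatter) in this assay, this chain position proves able to move the number beyond the scatter, which the earlier compounds could not show, since their only step, a 10-fold higher number from compound 2 to compound 3 (1.01 log units; beyond the scatter), concerns a different site on the aromatic nitrogen. The change is dimethylamino in place of (4-methylpiperazin-1-yl)methyl on a saturated chain carbon, four bonds along the chain from an aromatic nitrogen, so 3 heavy atoms replace 8 and the six-membered non-aromatic ring is lost, all within this one pair. No measurement on hand gives a cause for the step.

The compounds shown leave open whether the step follows the loss of the ring, the smaller group or the change in the amine itself, as these travel together in compound 1 and compound 4. A morpholine ring or a diethylamino group at the same chain carbon, or a longer chain ending in dimethylamino, would begin to separate these possibilities.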